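This account rests on a few compounds, and the source may have more. Where it says the series, first, only, none or still open, it means among the compounds named here.

In a functional assay on MGC-803 cells (Homo sapiens) for inhibition, read by MTT assay, with a stated time of 48 h (on this read-out lower numbers stand for stronger inhibition and higher numbers for weaker inhibition), compound 1 (`COCC(=O)N(Cc1ccc(OC)c(O)c1)c1cc(OC)c(OC)c(OC)c1`) gives 79 nM. This is the lower of the two true numbers available. Compound 2 (`C/C=C/C(=O)N(Cc1cc(OC)c(OC)c(OC)c1)c1ccc(OC)c(O)c1`) gives 6150 nM, and that gap lies well beyond the scatter of repeated measurements. Compound 3 (`COc1cc(NCc2ccc(Br)cc2)cc(OC)c1OC`) gives > 80000 nM, which is a limit of the assay and not a number.

The next compound to be read, compound 4 (`CCC/C=C/C(=O)N(Cc1ccc(OC)c(O)c1)c1cc(OC)c(OC)c(OC)c1`), keeps the core of compound 1 and changes one group. Pent-1-en-1-yl stands in place of methoxymethyl on a carbonyl carbon whose other neighbour is the amide-type nitrogen: pent-1-en-1-yl in place of methoxymethyl on a carbonyl carbon. Going by the values given here, no measured pair in this set tests that change, so the expectation rests on little. Among the compounds with values here, compound 1 already sits low in this assay, and the only other number, that of compound 2 at 6150 nM, lies higher, so a rise in the number looks more likely than a further fall. A moderate loss of inhibition is expected, clearly beyond the scatter but not reaching the limit seen for compound 3. The expected change is a 6.3-fold higher number from compound 1 to compound 4 (0.80 log units; beyond the scatter). For compound 4 the estimated value is 500 nM, with an expected range from 80 nM to 4000 nM.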

Compound 4, half-maximal inhibitory concentration: 70 nM
For compound 4 the middle estimate is 7.1-fold (0.85 log units) above the measured one; the whole stated range lies above it.
By their numbers in this assay, from the lowest: compounds 4 and 1 (each within the scatter of the next); then compound 2. At a limit, above all of these: compound 3.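

In this assay the carbonyl carbon whose other neighbour is the amide-type nitrogen takes pent-1-en-1-yl in place of methoxymethyl, with a 1.1-fold lower number from compound 1 to compound 4 (0.05 log units; within the scatter) as the step for this change. Going by these compounds alone, this is the first comparison in the set that isolates this place, and it shows that methoxymethyl, with its oxygen and its hydrogen-bond acceptor, can leave and the larger pent-1-en-1-yl, with its double bond, can enter without a shift beyond the scatter. Nothing measured here accounts for why the two groups read alike.

Going by these compounds, whether the same holds for other kinds of group stays open, such as an amine or a carboxylic acid at the end of the chain on this carbonyl carbon, or a chain longer than pent-1-en-1-yl. The part played by the double bond also cannot be told from these compounds, and a saturated pentyl chain in the same place would separate it from the effect of chain length alone.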